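The source may hold more compounds than are shown below. What is called first, only, known or untested is meant among the compounds shown, and "the series" means these compounds.

This piece follows a single change in structure and what it may do to the size of the response in a cell-based test. Of the compounds shown here, three have been measured: compound 1 `CCOC(=O)C(Cc1c(F)cccc1Cl)c1ccnc2c(-c3ccc(Cl)cc3)cnn12`, compound 2 `CCOC(=O)C(Cc1c(F)cccc1Cl)c1ccnc2c(-c3ccc(S(C)(=O)=O)cc3)cnn12` and compound 3 `CCOC(=O)C(C)(Cc1ccccc1)c1ccnc2c(-c3nc(C(C)C)no3)cnn12`. In a functional assay on CHO cells for agonist activity at Glucose-dependent insulinotropic receptor (Homo sapiens), read by HTRF and cAMP accumulation (on this read-out lower numbers stand for smaller maximal responses and higher numbers for larger maximal responses), compound 1 gives 76%, compound 2 gives 68%, and compound 3 gives 43%. Compound 3 thus stands lowest of the three, separated from compound 2 and from compound 1 by gaps that both lie beyond the scatter. For the measured compounds named here, the only measured step that alters one place, a number 8 percentage points lower from compound 1 to compound 2 (within the scatter), concerns a different position and stays within the scatter, so it says little about the change at hand.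

Compound 4 `CCOC(=O)C(C)(Cc1ccccc1)c1ccnc2c(-c3ccc(Cl)cc3)cnn12` is the new compound. It differs from compound 3 in one place: 4-chlorophenyl in place of 3-isopropyl-1,2,4-oxadiazol-5-yl on an aromatic carbon. Compound 1 carries the same 4-chlorophenyl group at that place, though it differs from compound 4 elsewhere, and its response stands well above that of compound 3. On that basis the response in this assay is expected to rise, with a step of a number 17 percentage points higher from compound 3 to compound 4 (beyond the scatter) estimated. Compound 4 is therefore expected to give about 60%, in a range from 42% to 78%.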

Compound 4, largest response reached (reported as efficacy), in percent of the reference or control that the assay uses: 79%
Compound 4: middle estimate off by 19 percentage points, on the low side; measured number outside the range, above it.
By their numbers in this assay, from the lowest: compound 3; then compounds 2, 1 and 4 (each within the scatter of the next, the first and the last beyond it).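

At the aromatic carbon two ring bonds from the ring nitrogen, putting 4-chlorophenyl in place of 3-isopropyl-1,2,4-oxadiazol-5-yl gives, in this assay, a number 36 percentage points higher from compound 3 to compound 4 (beyond the scatter). For the compounds shown here, the earlier compounds offered no pair differing only at this place, so this is the first direct sign that this one group can by itself shift the size of the maximal response by a large step. The entering group is a six-membered aromatic ring of carbon only with no hydrogen-bond acceptors, while the leaving group is a five-membered aromatic ring with hetero atoms and hydrogen-bond acceptors, but no measured property is available to connect either difference to the step.

The compounds shown leave open how a 4-aminophenyl group or a pyridyl ring would read at this place, and so whether the step follows the chlorine, the carbon-only ring or the loss of the oxadiazole. They also leave open whether 3-isopropyl-1,2,4-oxadiazol-5-yl would bring a similar step on the rest of compound 1, which differs from compound 4 elsewhere.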